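Working notes: from compound 2 to compound 3

The compounds below may be only part of what the source reports. "The series", "measured", "known", "first", "only" and "open" are said of these compounds alone.

- Compound 1 `COc1ccc(S(=O)(=O)N2CCc3cccc(-c4ccc(F)nc4)c32)cc1` gives 145 nM in a functional assay on MKN-45 cells (Homo sapiens) for inhibition, with a stated time of 72 h; on this read-out higher numbers stand for weaker inhibition and lower numbers for stronger inhibition
- Compound 2 `COc1ccc(S(=O)(=O)N2CCc3cccc(-c4ccc([N+](=O)[O-])cc4)c32)cc1` gives 34 nM in this assay
- Compound 3 `COc1ccc(S(=O)(=O)N2CCc3cccc(-c4ccc(F)c(F)c4)c32)cc1` is not yet measured

Compound 2 stands lowest of the two measured compounds, at 34 nM in this assay, and its gap to compound 1 lies beyond the scatter. The next change is 3,4-difluorophenyl in place of 4-nitrophenyl on an aromatic carbon on an aromatic carbon of a six-membered aromatic ring of carbon only, part of a fused or bridged system of two rings. Within the data shown here, one measured step bears on it: a 4.3-fold lower number from compound 1 to compound 2 (0.63 log units; beyond the scatter) with 4-nitrophenyl in place of 6-fluoropyridin-3-yl, a modest step. Compound 3 gives up the 4-nitrophenyl group and, like compound 1, carries a fluorinated ring there, so part of the step of a 4.3-fold lower number from compound 1 to compound 2 (0.63 log units; beyond the scatter) is expected to be reversed. Among the measured compounds shown here, no measured compound carries the 3,4-difluorophenyl group, so this expectation is loose. A modest rise is expected, a 2.2-fold higher number from compound 2 to compound 3 (0.34 log units; beyond the scatter) in this assay, with the direction less certain than usual. Compound 3 is estimated at 75 nM, with an expected range from 25 nM to 220 nM.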

Compound 3, half-maximal inhibitory concentration: 55.5 nM
The estimate for compound 3 lay 1.4-fold (0.13 log units) above the measured number; the range from low to high includes it.
By their numbers in this assay, from the lowest: compounds 2 and 3 (each within the scatter of the next); then compound 1.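

In this assay, the change to 3,4-difluorophenyl gives a 1.6-fold higher number from compound 2 to compound 3 (0.21 log units; within the scatter), so at this aromatic carbon the 4-nitrophenyl group, with its nitrogen, oxygens and hydrogen-bond acceptors, is not needed to keep the number in this range. The change from 6-fluoropyridin-3-yl to 3,4-difluorophenyl gives a 2.6-fold lower number from compound 1 to compound 3 (0.42 log units; beyond the scatter), which means that a fluorine on the ring does not by itself bring the number back to that of compound 1, and that among these three compounds the two with a six-membered aromatic ring of carbon only stand apart from the one with the fluoropyridine. No measurement at hand accounts for either step.

As far as these compounds go, it remains open whether an unsubstituted phenyl, a phenyl with a single fluorine, or a phenyl carrying an amine or a carboxylic acid would stay with compound 2 and compound 3 or move towards compound 1. The compounds shown also keep the methoxy group and the shared core unchanged, so it is unknown whether this reading at the aromatic carbon would hold with a different group in place of the methoxy.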